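Replacing thiophen-2-yl with 4-acetamidophenyl in compound 2

This account rests on a few compounds, and the source may have more. Where it says the series, first, only, none or still open, it means among the compounds named here.

Compound 1 `CC(C)C[C@H](NC(=O)CSc1cc(NS(=O)(=O)c2ccccc2)c2ccccc2c1O)B(O)O` gives 10600 nM
Compound 2 `CC(C)C[C@H](NC(=O)CSc1cc(NS(=O)(=O)c2cccs2)c2ccccc2c1O)B(O)O` gives 6520 nM

In a functional assay on MDA-MB-231 cells (Homo sapiens) for antiproliferative activity, read by sulforhodamine B assay, with a stated time of 72 h (a higher number here means a weaker inhibitor, a lower number a stronger inhibitor), compound 2 gives 6520 nM and sits within the scatter of compound 1. Compound 3 `CC(=O)Nc1ccc(S(=O)(=O)Nc2cc(SCC(=O)N[C@@H](CC(C)C)B(O)O)c(O)c3ccccc23)cc1` differs from compound 2 in one place, counted as 4-acetamidophenyl in place of thiophen-2-yl on a sulfonyl sulfur and put simply as 4-acetamidophenyl in place of thiophen-2-yl on a sulfonyl sulfur. Within the data shown here, the only measured guide is a single step at that same place, a 1.6-fold lower number from compound 1 to compound 2 (0.21 log units; within the scatter) for thiophen-2-yl in place of phenyl. Among the measured compounds shown here, no measured compound carries 4-acetamidophenyl, so the guide is thin. From that one step, no change beyond the scatter is expected in this assay in either direction. The expected step is a 1.1-fold higher number from compound 2 to compound 3 (0.03 log units; within the scatter) and it carries wide uncertainty. Compound 3 is estimated at 7000 nM with 2500 nM to 18000 nM as its expected range.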

Compound 3, half-maximal inhibitory concentration: 4450 nM
Beside the measured number, compound 3's estimate is 1.6-fold (0.20 log units) above it; low and high end bracket the measured number.
By their numbers in this assay, from the lowest: compounds 3, 2 and 1 (each within the scatter of the next, the first and the last beyond it).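

In this assay, among these compounds, the sulfonyl sulfur tolerates a much bigger group than the earlier compounds showed: 4-acetamidophenyl has 10 heavy atoms against 5 for thiophen-2-yl, yet the swap gives a 1.5-fold lower number from compound 2 to compound 3 (0.17 log units; within the scatter). Among the compounds shown here, the clearer result comes from adding acetamido to the phenyl group, which gives a 2.4-fold lower number from compound 1 to compound 3 (0.38 log units; beyond the scatter), a modest step but the first single change here to go beyond the scatter. Nothing available explains why this addition shifts the antiproliferative number.

The compounds shown leave open whether this shift is specific to acetamido or whether a simple amine or a carboxylic acid in its place would give a similar step. They also leave open whether an open chain such as methyl or butyl could replace the aromatic ring on the sulfonyl sulfur.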